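The source may report more compounds than this note shows. Statements on the series, on what has been measured and on what is new or still open speak of the compounds shown alone.

Measured compounds:
compound 1, `O=C(Nc1cccc(-c2oc3cc(-c4ccc(F)cc4)ccc3c(=O)c2O)c1)c1ccc(F)cc1F`, 6980 nM in a functional assay on HCC1937 cells (Homo sapiens) for antiproliferative activity, read by CCK-8 assay, with a stated time of 72 h; a lower number here means a stronger inhibitor, a higher number a weaker inhibitor
compound 2, `COc1cccc(C(=O)Nc2cccc(-c3oc4cc(-c5ccc(F)cc5)ccc4c(=O)c3O)c2)c1`, 18900 nM
compound 3, `Cc1cc(C(=O)Nc2cccc(-c3oc4cc(-c5ccc(F)cc5)ccc4c(=O)c3O)c2)ccc1F`, 5420 nM

Among these three, compound 3 gives the lowest number, but its gap to compound 1 lies within the scatter, so the two cannot be ordered against each other. Only compound 2 stands clearly apart, as the step of a 3.5-fold lower number from compound 2 to compound 3 (0.54 log units; beyond the scatter) shows. Compound 4, `O=C(Nc1cccc(-c2oc3cc(-c4ccc(F)cc4)ccc3c(=O)c2O)c1)c1ccc(Cl)nc1`, differs from compound 3 in a single place: 6-chloropyridin-3-yl in place of 4-fluoro-3-methylphenyl on a carbonyl carbon. For the measured compounds named here, the steps that bear on this change are the ones in which the same group on the carbonyl carbon was exchanged: a 1.3-fold lower number from compound 1 to compound 3 (0.11 log units; within the scatter), a 2.7-fold higher number from compound 1 to compound 2 (0.43 log units; beyond the scatter) and a 3.5-fold lower number from compound 2 to compound 3 (0.54 log units; beyond the scatter). Going by the values given here, every such exchange so far has moved the number by a modest amount at most, and none of the three earlier groups is a chloropyridinyl, so there is no direct precedent. A modest shift in either direction, or no step beyond the scatter, is therefore the reasonable expectation. Compound 4 is estimated to give 8000 nM, with a range from 3000 nM to 25000 nM. That estimate corresponds to an expected step of a 1.5-fold higher number from compound 3 to compound 4 (0.17 log units; within the scatter).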

Compound 4, half-maximal inhibitory concentration: 7550 nM
Beside the measured number, compound 4's estimate is 1.1-fold (0.03 log units) above it; the measured number falls inside the stated range.
By their numbers in this assay, from the lowest: compounds 3, 1 and 4 (each within the scatter of the next); then compound 2.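

In this assay, for the compounds shown here, the group on the carbonyl carbon can carry a ring nitrogen and a chlorine, which none of the carbon-only rings of the earlier compounds did, without a step beyond the scatter from either of the two closest compounds (a 1.4-fold higher number from compound 3 to compound 4 (0.14 log units; within the scatter); a 1.1-fold higher number from compound 1 to compound 4 (0.03 log units; within the scatter)). Going by these compounds alone, the 6-chloropyridin-3-yl group therefore joins 4-fluoro-3-methylphenyl and 2,4-difluorophenyl as a third group that cannot be ordered against the others, while 3-methoxyphenyl remains the only one of the four groups clearly apart, now also against this new ring (a 2.5-fold lower number from compound 2 to compound 4 (0.40 log units; beyond the scatter)). No measurement here accounts for the separate standing of compound 2 or for the closeness of the other three.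

The compounds shown leave open whether the ring nitrogen or the chlorine of compound 4 matters on its own, as an unsubstituted pyridin-3-yl or a 6-aminopyridin-3-yl ring would test. They also leave open whether a group of a different kind on this carbonyl carbon, such as a morpholine, a carboxylic acid or a longer alkyl chain, would move the number further than any step seen so far.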